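A Halogen Swap on the Aromatic Nitrogen, Transferred

The source may report more compounds than this note shows. Statements on the series, on what has been measured and on what is new or still open speak of the compounds shown alone.

Compound 1 `O=C(Nc1ccc(Oc2ccnc3[nH]ccc23)cc1)c1cc2cccnc2n(-c2ccc(Br)cc2F)c1=O` and compound 2 `O=C(Nc1ccc(Oc2ccnc3[nH]ccc23)cc1)c1cc2cccnc2n(-c2ccc(C(F)(F)F)cc2Cl)c1=O` share one core and differ only in 2-chloro-4-(trifluoromethyl)phenyl in place of 4-bromo-2-fluorophenyl on an aromatic nitrogen. In a functional assay on A549 cells (Homo sapiens) for antiproliferative activity, read by MTT assay, with a stated time of 72 h (a lower number here means a stronger inhibitor, a higher number a weaker inhibitor), compound 1 gives 1570 nM, while compound 2 gives 3230 nM, so the change produced a 2.1-fold higher number from compound 1 to compound 2 (0.31 log units; beyond the scatter). Compound 3 `Cn1ccc2c(Oc3ccc(NC(=O)c4cc5cccnc5n(-c5ccc(Br)cc5F)c4=O)cc3F)ccnc21` has a different core; the difference between the two cores is not broken down here. In this assay compound 3 gives 2690 nM, a value within the scatter of that of compound 2. Compound 4 `Cn1ccc2c(Oc3ccc(NC(=O)c4cc5cccnc5n(-c5ccc(C(F)(F)F)cc5Cl)c4=O)cc3F)ccnc21` arises from compound 3 by the same kind of change, (2-chloro-4-(trifluoromethyl)phenyl in place of 4-bromo-2-fluorophenyl on an aromatic nitrogen), at a place described in the same words. Going by the values given here, the step from compound 3 to compound 4 is expected to be a 2.1-fold higher number from compound 3 to compound 4 (0.32 log units; beyond the scatter), an estimate resting on a single precedent because a 2.1-fold higher number from compound 1 to compound 2 (0.31 log units; beyond the scatter) is the only measured instance of this change. Compound 4 is therefore expected near 5600 nM, likely between 2500 nM and 13000 nM.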

Compound 4, half-maximal inhibitory concentration: 3530 nM
For compound 4 the middle estimate is 1.6-fold (0.20 log units) above the measured one; measured number inside the range.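

In this assay the change gives a 1.3-fold higher number from compound 3 to compound 4 (0.12 log units; within the scatter). Set beside the earlier step, the two cores do not separate: the same change on two cores in this assay, a 2.1-fold higher number (0.31 log units; beyond the scatter) from compound 1 to compound 2 and a 1.3-fold higher number (0.12 log units; within the scatter) from compound 3 to compound 4, 1.6-fold (0.20 log units) apart, within the scatter of two such steps. This shows that, within this pair of cores, the step seen on the first core is compatible with the one seen on the second, but it does not establish a fixed size for the change, as one step lies beyond the scatter and the other within it, and two cores in one assay cannot support a rule for the series.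

The compounds shown leave open how other groups on the aromatic nitrogen, such as an unsubstituted phenyl or a pyridyl, would compare on these two cores. They also leave open whether the change would carry to a third core.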